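The source may hold more compounds than are shown below. What is called first, only, known or untested is meant among the compounds shown, and "the series" means these compounds.

Compound 1, `COc1ccccc1C[C@H]1C(=O)OC[C@@H]1Cc1ccccc1`, in a functional assay on HL-60 cells (Homo sapiens) for cytotoxicity, read by WST assay, with a stated time of 48 h (a higher number here means that more compound is needed for the effect, a lower number that less compound is needed), gives 79000 nM. Compound 2, `CCCCOc1ccccc1C[C@H]1C(=O)OC[C@@H]1Cc1ccccc1`, carries propyl in place of hydrogen on a saturated chain carbon bound to an oxygen on an aromatic ring and in this assay compound 2 gives 20000 nM, so that a 4.0-fold lower number from compound 1 to compound 2 (0.60 log units; beyond the scatter). Compound 3, `CCCCOc1cccc(C[C@H]2C(=O)OC[C@@H]2Cc2ccccc2)c1`, differs from compound 1 in its core, and the difference between the two cores is not broken down here; in this assay compound 3 gives 26000 nM, which against compound 2 is within the scatter, and against compound 1 beyond it.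

Compound 4, `CCCCCCCOc1cccc(C[C@H]2C(=O)OC[C@@H]2Cc2ccccc2)c1`, is not yet measured. It carries propyl in place of hydrogen on a saturated chain carbon, four bonds along the chain from an oxygen on an aromatic ring, the same kind of change as that from compound 1 to compound 2, though the place differs: there the propyl entered on a saturated chain carbon bound to an oxygen on an aromatic ring, here on a saturated chain carbon four bonds along the chain from an oxygen on an aromatic ring. If that kind of change carries over, a step of about a 3.3-fold lower number from compound 3 to compound 4 (0.51 log units; beyond the scatter) is expected in this assay, resting on the earlier step of a 4.0-fold lower number from compound 1 to compound 2 (0.60 log units; beyond the scatter) and on the value of compound 3, 26000 nM. Compound 4 is therefore estimated at 8000 nM, between 3000 nM and 20000 nM.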

Compound 4, half-maximal effective concentration: 81000 nM
The estimate for compound 4 lay 10-fold (1.01 log units) below the measured number; measured number outside the range, above it.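

Added to the core of compound 3, the propyl gave a 3.1-fold higher number from compound 3 to compound 4 (0.49 log units; beyond the scatter) in this assay, so the direction is opposite to that seen on the core of compound 1, and the two steps do not agree: the same change on two cores in this assay, a 4.0-fold lower number (0.60 log units; beyond the scatter) from compound 1 to compound 2 and a 3.1-fold higher number (0.49 log units; beyond the scatter) from compound 3 to compound 4, 12-fold (1.09 log units) apart, beyond the scatter of two such steps

This shows that the step seen on one core cannot be carried over to the other core in this series, either in size or in direction. For the compounds shown here, it does not show what lies behind the difference: there is only one pair for each core, and the core and the place of the propyl change together.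

Left open is whether a longer chain on the core of compound 1 would lower the number further, and whether a longer chain on the core of compound 3 would raise it further. Also open, as far as these compounds go, is how a chain carrying an amine or a carboxylic acid would behave on either core in this assay.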